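Removing the nitrile from the amino-pyridinone core

The source may hold more compounds than are shown below. What is called first, only, known or untested is meant among the compounds shown, and "the series" means these compounds.

Compound 1 `CC1(C)CC(=O)c2cc(C#N)c(NCc3ccccc3)nc2C1` gives 2500 nM in an in vitro functional assay on cells for antagonist activity at metabotropic glutamate receptor 1 (Rattus norvegicus), read by inositol phosphate accumulation; on this read-out lower numbers stand for stronger inhibition and higher numbers for weaker inhibition.
Compound 2 `CCCCNc1nc2c(cc1C#N)C(=O)CC(C)(C)C2` gives 1700 nM in this assay.
Compound 3 `CCCCCCNc1nc2c(cc1C#N)C(=O)CC(C)(C)C2` gives 2600 nM in this assay.

Among the three measured compounds, compound 1 stands with the second highest number. Its nearest neighbour is compound 3, and the whole spread of the set is small: the change from a 1.5-fold lower number from compound 1 to compound 2 (0.17 log units; within the scatter), the change from a 1.0-fold higher number from compound 1 to compound 3 (0.02 log units; within the scatter) and the change from a 1.5-fold higher number from compound 2 to compound 3 (0.18 log units; within the scatter) all stay within the scatter of repeated measurements, so nothing here separates benzyl, butyl and hexyl on the ring nitrogen.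

Compound 4 `CC1(C)CC(=O)c2ccc(NCc3ccccc3)nc2C1` differs from compound 1 in a different place: hydrogen in place of cyano on an aromatic carbon. In words, a hydrogen replaces the cyano on an aromatic carbon of the shared core.

Among the measured compounds shown here, none of the measured steps touches this position. Each of them alters only the chain on the saturated carbon bound to the aromatic nitrogen, and each is within the scatter. The data therefore give no direct guide to the size or direction of the step to compound 4. Because compound 1 gives 2500 nM and every measured step stays within the scatter, the expectation for compound 4 is anchored on that value, with a wide range to reflect the absence of a comparable change. Compound 4 is expected to give 6000 nM in this assay, within 1500 nM to 25000 nM, which is an expected step of a 2.4-fold higher number from compound 1 to compound 4 (0.38 log units; beyond the scatter).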

Compound 4, half-maximal inhibitory concentration: 45000 nM
Beside the measured number, compound 4's estimate is 7.5-fold (0.88 log units) below it; measured number outside the range, above it.
By their numbers in this assay, from the lowest: compounds 2, 1 and 3 (each within the scatter of the next); then compound 4.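

In this assay, among the compounds shown here, hydrogen in place of cyano on an aromatic carbon is the first change in this set to move the number beyond the scatter, and the step is large (an 18-fold higher number from compound 1 to compound 4 (1.26 log units; beyond the scatter)). The earlier steps altered only the chain on the nitrogen, and benzyl, butyl and hexyl could not be told apart there, so among these four compounds this position, two atoms from the ring nitrogen, is the one where a single change clearly weakens inhibition, with the nitrile present in the stronger partner of the pair. Nothing available here accounts for the size of this step.

The compounds shown leave open whether another group on this aromatic carbon, such as a primary amide, a carboxylic acid or a chlorine atom, would hold the number near that of compound 1 or let it rise toward that of compound 4. On these data alone, it also remains open whether hydrogen in place of cyano would give a step of similar size with the butyl chain of compound 2 or the hexyl chain of compound 3 on the nitrogen.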